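This account rests on a few compounds, and the source may have more. Where it says the series, first, only, none or still open, it means among the compounds named here.

Going by the values given here, in a functional assay on PC-3 cells (Homo sapiens) for antiproliferative activity, read by sulforhodamine B assay, with a stated time of 48 h (a lower number here means a stronger inhibitor, a higher number a weaker inhibitor), two compounds built on the same core have numbers so far. Compound 1 `O=C(CCCCCCN1C(=O)/C(=N\O)c2cc(Cl)ccc21)NO` gives 850 nM, and compound 2 `O=C(CCCCCCN1C(=O)/C(=N\O)c2cc([N+](=O)[O-])ccc21)NO` gives 19700 nM. Compound 2 therefore holds the higher of the two numbers, making it the weaker inhibitor of the pair. Among the compounds with values here, the single measured step is nitro in place of chloro on an aromatic carbon, and it is large and beyond the scatter: a 23-fold higher number from compound 1 to compound 2 (1.37 log units; beyond the scatter).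

Compound 3 `Cc1ccc2c(c1)/C(=N/O)C(=O)N2CCCCCCC(=O)NO` has methyl in place of nitro on an aromatic carbon. The step from compound 1 is the only one that bears on this change, since it is the step that introduced the nitro group. Within the data shown here, no methyl compound has yet been measured, so this evidence is indirect. A sizeable move to a lower number is nevertheless expected in this assay, probably somewhat short of full return to the level of compound 1 at 850 nM. The estimate amounts to an expected 9.9-fold lower number from compound 2 to compound 3 (0.99 log units; beyond the scatter). The estimated value for compound 3 is 2000 nM, with an expected range of 600 nM to 8000 nM.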

Compound 3, half-maximal inhibitory concentration: 620 nM
Compound 3: middle estimate off by 3.2-fold (0.51 log units), on the high side; low and high end bracket the measured number.
By their numbers in this assay, from the lowest: compounds 3 and 1 (each within the scatter of the next); then compound 2.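

In this assay, methyl in place of nitro on an aromatic carbon gives a 32-fold lower number from compound 2 to compound 3 (1.50 log units; beyond the scatter) as a large step, whereas methyl in place of chloro gives a 1.4-fold lower number from compound 1 to compound 3 (0.14 log units; within the scatter) at the same place. The earlier pair showed only that chloro and nitro lie far apart, and could not tell whether chloro or nitro was the unusual member; with a third group on that carbon, compound 2 stands alone, while compound 1 and compound 3 cannot be told apart. Among these three compounds, then, the high number goes with the nitro group alone, and this position tolerates an exchange of chloro for methyl without a change beyond the scatter.

Nothing in the data given explains why nitro differs from the other two groups. Going by these compounds, whether an amine, a methoxy group or a carboxylic acid on this aromatic carbon would stay with chloro and methyl or go with nitro remains open, as does whether the same gap would persist on the shared core with a longer chain before the hydroxamic acid end.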